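The source may report more compounds than this note shows. Statements on the series, on what has been measured and on what is new or still open speak of the compounds shown alone.

Measured in a functional assay on ileum for antagonist activity at muscarinic acetylcholine receptor M3 (Cavia porcellus); on this read-out higher numbers stand for weaker inhibition and lower numbers for stronger inhibition:
- compound 1 `C#CCN1CCN(CC(=O)C(O)(c2ccccc2)C2CCCCC2)CC1` gives 260 nM
- compound 2 `O=C(CN1CCN(C/C=C\c2ccccc2)CC1)C(O)(c1ccccc1)C1CCC1` gives 9.92 nM
- compound 3 `O=C(CN1CCC(N2CCCC2)CC1)C(O)(c1ccccc1)C1CCC1` gives only > 10000 nM, which is a limit of the assay and not a number

Among the two numbers, compound 2 has the lowest, so the strongest inhibition; compound 1 sits at a higher number, a gap beyond the usual scatter. Compound 3 reaches only the assay limit, as the line the limit of > 10000 nM in this assay, at which 1 of the 3 values shown sits, records.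

Compound 4 `CCOc1ccccc1N1CCN(CC(=O)C(O)(c2ccccc2)C2CCC2)CC1` differs from compound 2 in one place: 2-ethoxyphenyl in place of 3-phenylprop-2-en-1-yl on an amine nitrogen in a ring. Within the data shown here, no measured pair shows this kind of change, so its effect is open. A moderate weakening in this assay seems the more likely outcome, and the expected step of a 10-fold higher number from compound 2 to compound 4 (1.00 log units; beyond the scatter) is a rise in the number. The estimate for compound 4 is 100 nM, within 15 nM to 1000 nM.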

Compound 4, antagonist equilibrium constant: > 10000 nM
Compound 4 was reported as a limit; the forecaster's own chance of this, stated with the estimate: 10%; middle value at least 100-fold (2.00 log units) away from the limit.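

In this assay compound 4 reaches only a limit of the assay, not a number, as compound 3 does: the limit of > 10000 nM in this assay, at which 2 of the 4 values shown sit.

On the amine nitrogen of the ring, putting 2-ethoxyphenyl in place of 3-phenylprop-2-en-1-yl brings an at least 1000-fold higher number from compound 2 to compound 4 (3.00 log units; beyond the scatter). Both groups have the same heavy-atom count and one aromatic ring of carbon, so neither that count nor the presence of such a ring is enough to keep the activity.

From the compounds shown here alone, it stays open whether the loss follows the ethoxy group or the missing chain that carries the ring. An unsubstituted phenyl or a benzyl group on that nitrogen would separate the two.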